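Swapping Chloro for Trifluoromethyl in Compound 3

The compounds below may be only part of what the source reports. "The series", "measured", "known", "first", "only" and "open" are said of these compounds alone.

Measured so far in a functional assay on CHO cells for inhibition of transient receptor potential cation channel subfamily V member 1 (Homo sapiens); a higher number here means a weaker inhibitor, a lower number a stronger inhibitor:
Compound 1 `O=C(/C=C/c1ccccc1)Nc1ccc2c(c1)OCCO2` gives > 4000 nM.
Compound 2 `O=C(/C=C/c1ccc(Cl)cc1)Nc1ccc2c(c1)OCCO2` gives 250 nM.

Among the compounds with values here, compound 2 holds the only numerical value in this assay. Compound 1 sits at the limit of > 4000 nM in this assay, at which 1 of the 2 values shown sits, which is a limit of the assay and not a number. Within the data shown here, the one measured step, an at least 16-fold lower number from compound 1 to compound 2 (1.20 log units; beyond the scatter), is large and shows that what stands at this aromatic position can move the result strongly. Compound 3 `O=C(/C=C/c1ccc(C(F)(F)F)cc1)Nc1ccc2c(c1)OCCO2` carries trifluoromethyl in place of chloro on an aromatic carbon. Among the measured compounds shown here, the measured step compared hydrogen with chloro, not chloro with trifluoromethyl, so it bears on the exchange only loosely, and no other step addresses it. The expected outcome is therefore a step within the scatter, with no firm direction. Compound 3 is expected to give about 200 nM, within 60 nM to 700 nM. The estimated step is a 1.3-fold lower number from compound 2 to compound 3 (0.10 log units; within the scatter).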

Compound 3, half-maximal inhibitory concentration: 46 nM
The estimate for compound 3 lay 4.3-fold (0.64 log units) above the measured number; measured number outside the range, below it.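

In this assay, within the data shown here, the earlier compounds showed only that chloro differs from hydrogen on this aromatic carbon, whereas exchanging chloro for trifluoromethyl now gives a 5.4-fold lower number from compound 2 to compound 3 (0.74 log units; beyond the scatter). The position therefore separates one substituent from another and does not merely respond to the loss of hydrogen, and replacing hydrogen with trifluoromethyl gives an at least 86-fold lower number from compound 1 to compound 3 (1.93 log units; beyond the scatter). That step has only a lower bound, since compound 1 stands at a limit of the assay and not at a number: the limit of > 4000 nM in this assay, at which 1 of the 3 values shown sits.

The compounds shown leave open how a methoxy group, a nitrile or an amine at this place would compare with trifluoromethyl. They also do not show whether chloro or trifluoromethyl on another carbon of this aromatic ring would give a similar result.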